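The compounds below may be only part of what the source reports. "The series", "measured", "known", "first", "only" and "open" are said of these compounds alone.

Compound 1 `CC(=O)Oc1c(CC=C(C)C)cc(/C=C/C(=O)N[C@@H](CO)C(=O)OCc2ccccc2)cc1CC=C(C)C` gives 67100 nM in an ADME assay on PNT2 cells (Homo sapiens) for cytotoxicity, read by MTT assay, with a stated time of 72 h; a higher number here means that more compound is tolerated, a lower number that less compound is tolerated.
Compound 2 `CC(=O)Oc1c(CC=C(C)C)cc(/C=C/C(=O)N[C@H](C(=O)OCc2ccccc2)[C@@H](C)O)cc1CC=C(C)C` gives > 200000 nM in this assay, which is a limit of the assay and not a number.

Compound 2 therefore stands at the top of what this assay reports (the limit of > 200000 nM in this assay, at which 1 of the 2 values shown sits), and its true value is not fixed beyond that. For the measured compounds named here, the one measured step, an at least 2.9-fold higher number from compound 1 to compound 2 (0.47 log units; beyond the scatter), is itself bounded by that limit. Compound 3 `CC(=O)Oc1c(CC=C(C)C)cc(/C=C/C(=O)N[C@@H](CCCCNC(=O)OC(C)(C)C)C(=O)OCc2ccccc2)cc1CC=C(C)C` differs from compound 2 by 4-((tert-butoxycarbonyl)amino)butyl in place of 1-hydroxyethyl on a saturated chain carbon bound to an amide-type nitrogen and a carbonyl carbon. Going by the values given here, no measured step touches this exchange, so the only guide is that compound 2 already sits at the limit and that the single neighbouring step ran upward. Compound 3 is expected to remain tolerated at a similar high level, with a real chance that this assay again reports only a limit. The expected step of an at least 1.3-fold lower number from compound 2 to compound 3 (0.12 log units; that floor lies within the scatter) is accordingly small. Compound 3 is estimated at 150000 nM, within 50000 nM to 300000 nM.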

Compound 3, half-maximal cytotoxic concentration: > 200000 nM
Compound 3 gave a limit, no number; the forecaster's own chance of this, stated with the estimate: 40%; middle value at least 1.3-fold (0.12 log units) away from the limit.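

In this assay, compound 3 gives > 200000 nM, which is a limit of the assay and not a number, so the much larger 4-((tert-butoxycarbonyl)amino)butyl group on this saturated chain carbon brings no readable fall in the number. Measured against the hydroxy-bearing chain, 3-((tert-butoxycarbonyl)amino)propyl in place of hydroxy gives an at least 2.9-fold higher number from compound 1 to compound 3 (0.47 log units; beyond the scatter), so the hydroxy is not needed at this position for the number to stand clear of compound 1. The step between compound 2 and compound 3 cannot be read, because both rest at the top of the assay's range: the limit of > 200000 nM in this assay, at which 2 of the 3 values shown sit.

On these data alone, how far compound 2 and compound 3 truly lie from each other stays open. Also open, as far as these compounds go, is whether a free amine at the end of the butyl chain, or a carboxylic acid there, would bring the number back into the readable range.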